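From Methoxy to Hydroxy: Expecting Another Limit

The source may report more compounds than this note shows. Statements on the series, on what has been measured and on what is new or still open speak of the compounds shown alone.

Compound 1 `O=C(Nc1cccc(-n2cc(-c3ccncc3)c(-c3ccc(Cl)c(O)c3)n2)c1)Nc1cccc(C(F)(F)F)c1`: > 32500 nM
Compound 2 `O=C(Nc1cccc(-n2cc(-c3ccncc3)c(-c3ccc(Cl)c(O)c3)n2)c1)Nc1ccc(Cl)c(Cl)c1`: > 32500 nM
Compound 3 `COc1cc(-c2nn(-c3cccc(NC(=O)Nc4ccc(Cl)c(C(F)(F)F)c4)c3)cc2-c2ccncc2)ccc1Cl`: > 32500 nM

Of the compounds shown here, three have been tested in a functional assay on CCRF-CEM cells (Homo sapiens) for inhibition, read by sulforhodamine B assay, with a stated time of 48 h (on this read-out lower numbers stand for higher toxicity in this test and higher numbers for lower toxicity in this test), and none of them produced a number. For compound 1 the entry > 32500 nM is a limit of the assay, not a measured value. For compound 2 the entry > 32500 nM is likewise only a limit. For compound 3 the entry > 32500 nM is again a limit. Among the measured compounds shown here, the only single-point change among the measured compounds, a step that the two limits leave unreadable from compound 1 to compound 2, therefore cannot be read in size or direction. All that is known is the limit of > 32500 nM in this assay, at which 3 of the 3 values shown sit.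

Compound 4 `O=C(Nc1cccc(-n2cc(-c3ccncc3)c(-c3ccc(Cl)c(O)c3)n2)c1)Nc1ccc(Cl)c(C(F)(F)F)c1` has not yet been tested. It differs from compound 3 in one place: hydrogen in place of methyl on an oxygen on an aromatic ring. Since every measured compound sits at the same limit, nothing here points to a gain or loss beyond the scatter, and the expected step that the limit leaves unreadable from compound 3 to compound 4 from compound 3 to compound 4 is essentially flat. Compound 4 is therefore estimated at 40000 nM, within 15000 nM to 100000 nM, with the most likely outcome being that this assay again reports only a limit.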

Compound 4, concentration lethal to 50% of the cells: > 32500 nM
Compound 4: only a limit was reported (the forecaster's own chance of this, stated with the estimate: 75%); the middle value lies beyond the limit too.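

Compound 4 also ends at a limit, so its steps from compound 1, compound 2 and compound 3 cannot be read in size or direction: the limit of > 32500 nM in this assay, at which 4 of the 4 values shown sit.

The compounds shown leave open how toxic any of them really is in this assay and whether any single change to this series would give a measured number.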